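The source may report more compounds than this note shows. Statements on the series, on what has been measured and on what is new or still open speak of the compounds shown alone.

Measured in a functional assay on HCT-116 cells (Homo sapiens) for inhibition, read by MTT assay, with a stated time of 48 h (on this read-out higher numbers stand for weaker inhibition and lower numbers for stronger inhibition), so far:
compound 1 `COc1ccc(CN(C(=O)CO)c2cc(OC)c(OC)c(OC)c2)cc1O` gives 520 nM
compound 2 `COc1ccc(CN(C(=O)CCCCCl)c2cc(OC)c(OC)c(OC)c2)cc1O` gives 220 nM

Among the measured compounds shown here, of these two, compound 2 holds the lower number (220 nM) and so the stronger inhibition, and compound 1 is its only neighbour. The next compound, compound 3 `COc1ccc(CN(C(=O)C2CC2)c2cc(OC)c(OC)c(OC)c2)cc1O`, keeps the shared core and has cyclopropyl in place of 4-chlorobutyl on a carbonyl carbon. For the measured compounds named here, no measured step covers this exchange directly. Going by the values given here, the one step that bears on it, a 2.4-fold lower number from compound 1 to compound 2 (0.37 log units; beyond the scatter), also changes the group on the carbonyl carbon; it is modest but beyond the scatter. That single comparison gives little to go on, and it says nothing about a ring in this place. Since compound 2 stands lowest at 220 nM, a modest move towards a higher number in this assay is the more likely outcome, of about the size already seen. The expected step is a 2.2-fold higher number from compound 2 to compound 3 (0.34 log units; beyond the scatter), an estimate and no more. Compound 3 is estimated at 480 nM, with an expected range from 150 nM to 1500 nM, pending its measurement.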

Compound 3, half-maximal inhibitory concentration: 49 nM
Compound 3: the middle estimate sits 9.8-fold (0.99 log units) above what was measured, and the stated range ends above it.
By their numbers in this assay, from the lowest: compound 3; then compound 2; then compound 1.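

In this assay, the group on the carbonyl carbon turns out to matter more than the first step suggested: the exchange of hydroxymethyl for cyclopropyl gives an 11-fold lower number from compound 1 to compound 3 (1.03 log units; beyond the scatter), a large step, where the exchange for 4-chlorobutyl had been only modest. The earlier step could have been read as favouring a longer chain at this place, but compound 3 goes against that reading: cyclopropyl has fewer heavy atoms than 4-chlorobutyl and no chlorine, and the exchange still gives a 4.5-fold lower number from compound 2 to compound 3 (0.65 log units; beyond the scatter), so a longer chain is not needed for a low number here. Nothing available explains why this three-membered ring gives the lowest number of the three compounds.

Among the compounds shown here, with only three groups at this place, the compounds leave open whether the gain belongs to the ring itself or simply to a short carbon group, which isopropyl or cyclobutyl on the same carbonyl carbon would help to separate. They also leave open how far this place tolerates other kinds of group, such as an amine or a carboxylic acid at the end of a short chain, or a larger ring such as cyclohexyl.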